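A few compounds are considered here, and "the series" means these few. Any claim that something is new, unique, unknown or untested is made for them only; others in the source may bear on it.

Measured so far:
compound 1, `Cc1ccc(C)c(-c2n[nH]c(-c3ccccc3)n2)c1`, gives > 10 mg/kg in a functional assay on the whole organism (Cricetulus griseus) with Cricetinae gen. sp. as the target; on this read-out higher numbers stand for an effect only at larger amounts of compound and lower numbers for an effect already at smaller amounts.
compound 2, `COc1ccc(C)c(-c2n[nH]c(-c3ccccc3)n2)c1`, gives > 10 mg/kg in this assay.
compound 3, `COc1cccc(-c2n[nH]c(-c3cc(C)ccc3C)n2)c1`, gives 2.5 mg/kg in this assay.

For compound 1 the value is a limit of the assay and not a number. For compound 2 the value is likewise a limit of the assay and not a number. Compound 3 is the only one of the three with a number; the other two sit at the limit of > 10 mg/kg in this assay, at which 2 of the 3 values shown sit.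

Compound 2 differs from compound 1 by methoxy in place of methyl on an aromatic carbon. The step this change made, a step that the two limits leave unreadable from compound 1 to compound 2, cannot be read, since both ends are limits.

Compound 4, `COc1cccc(-c2n[nH]c(-c3cc(OC)ccc3C)n2)c1`, has not been measured. It differs from compound 3 by methoxy in place of methyl on an aromatic carbon. The change and its place are the same as between compound 1 and compound 2. How the core of compound 3 differs from the core of compound 1 is not broken down here.

Among the compounds with values here, what the one readable pair can say about this change is nothing, so the expectation for compound 4 rests on compound 3 alone, whose value in this assay is 2.5 mg/kg. The step expected in this assay is a 1.4-fold higher number from compound 3 to compound 4 (0.15 log units; within the scatter), a small one, drawn wide for want of a measured step of this kind. Compound 4 is expected to give about 3.5 mg/kg in this assay, estimated between 1.5 mg/kg and 10 mg/kg.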

Compound 4, dose for half-maximal effect: 1 mg/kg
For compound 4 the middle estimate is 3.5-fold (0.54 log units) above the measured one, and the stated range ends above it.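

Where the change can be read, methoxy in place of methyl on an aromatic carbon gave a 2.5-fold lower number from compound 3 to compound 4 (0.40 log units; beyond the scatter) in this assay, so on this one core the swap goes with an effect at smaller amounts of compound. The same change on the core of compound 1 cannot be read, as the values of compound 1 and compound 2 are each a limit of the assay and not a number: the limit of > 10 mg/kg in this assay, at which 2 of the 4 values shown sit. The series therefore shows the step on a single core only; it neither confirms nor rules out that the change carries from one core to another, and the failure of compound 2 to give a number says nothing about the size or direction of the change on its core.

The compounds shown carry only methyl or methoxy at the place para to a methyl group, so it stays open whether the step belongs to methoxy in particular or would also appear with a longer chain such as ethoxy, with a hydroxyl, or with an amine or a carboxylic acid. On these data alone, it also stays open how any of these groups would read in this assay on the core of compound 1.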